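A few compounds are considered here, and "the series" means these few. Any claim that something is new, unique, unknown or untested is made for them only; others in the source may bear on it.

In a functional assay on SK-OV-3 cells (Homo sapiens) for cytotoxicity, read by MTT assay, with a stated time of 48 h (a higher number here means a weaker inhibitor, a lower number a stronger inhibitor), compound 3 `C=CCn1c(-c2ccc(OC)cc2C=C)cc2ccccc2c1=O` gives 43800 nM and compound 2 `C=CCn1c(-c2cc(OC)c(OC)cc2C=C)cc2ccccc2c1=O` gives 35500 nM in the same test. The two differ by methoxy in place of hydrogen on an aromatic carbon and the step was a 1.2-fold lower number from compound 3 to compound 2 (0.09 log units; within the scatter) in size. Compound 1 `COCOCc1cc(OC)ccc1-c1cc2ccccc2c(=O)[nH]1` gives 75500 nM in this assay and stands with the highest of the three numbers, though its gap to compound 3 lies within the scatter and only its gap to compound 2 lies beyond it. The difference between the core of compound 1 and the core of compound 3 is not broken down here. Compound 4 `COCOCc1cc(OC)c(OC)cc1-c1cc2ccccc2c(=O)[nH]1` has not yet been measured in this assay and differs from compound 1 by methoxy in place of hydrogen on an aromatic carbon in the same kind of change seen from compound 3 to compound 2, with one difference around the place: in the measured pair the entering group sits para to a vinyl group, whereas in compound 4 it sits para to a (methoxymethoxy)methyl group. Because a 1.2-fold lower number from compound 3 to compound 2 (0.09 log units; within the scatter) was small, the step from compound 1 to compound 4 is expected to be of similar size, namely a 1.2-fold lower number from compound 1 to compound 4 (0.09 log units; within the scatter) in this assay. Compound 4 is therefore estimated at 62000 nM with a likely range from 30000 nM to 125000 nM in this assay.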

Compound 4, half-maximal inhibitory concentration: 87700 nM
The estimate for compound 4 lay 1.4-fold (0.15 log units) below the measured number; low and high end bracket the measured number.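

In this assay, methoxy in place of hydrogen, ortho to a methoxy group and para to a (methoxymethoxy)methyl group, gave a 1.2-fold higher number from compound 1 to compound 4 (0.07 log units; within the scatter). Set beside the earlier step on the other core, the change gives no sign of behaving differently from one core to the other: the same change on two cores in this assay, a 1.2-fold lower number (0.09 log units; within the scatter) from compound 3 to compound 2 and a 1.2-fold higher number (0.07 log units; within the scatter) from compound 1 to compound 4, 1.4-fold (0.16 log units) apart, within the scatter of two such steps. This shows that in these two pairs the change carried across with no step beyond the scatter, but the opposite directions of the two steps cannot be read as an effect of the core, and two pairs do not make a rule for the series.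

The compounds shown leave open whether another group at this place, such as an amine, a carboxylic acid or a longer alkoxy chain, would shift the number beyond the scatter. They also leave open how the core of compound 1 and the core of compound 3 compare, as these differ in more than one place.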